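The source may report more compounds than this note shows. Statements on the series, on what has been measured and on what is new or still open speak of the compounds shown alone.

Compounds measured so far:
Compound 1 `COc1cc(-c2nc3ccccc3s2)ccc1OCC(=O)NNC(O)CN(C)CC(=O)O`: 3030 nM
Compound 2 `COc1cc(-c2nc3ccccc3s2)ccc1OCC(=O)NNC(=O)CN(C(C)=O)[C@@H](CS)C(=O)O`: 3420 nM

Both compounds were tested in a functional assay on HepG2 cells (Homo sapiens) for inhibition, read by MTT assay, with a stated time of 3 days; a higher number here means a weaker inhibitor, a lower number a stronger inhibitor. Compound 2, at 3420 nM, lies within the usual scatter of compound 1, at 3030 nM, so the two numbers cannot be told apart.

Compound 3 `CCOC(=O)[C@H](CS)NCC(=O)NNC(=O)COc1ccc(-c2nc3ccccc3s2)cc1OC` has not yet been measured. It differs from compound 2 in one place, a saturated chain carbon bound to a carbonyl carbon, where (1-(ethoxycarbonyl)-2-sulfanylethyl)amino stands in place of acetyl(1-carboxy-2-sulfanylethyl)amino ((1-(ethoxycarbonyl)-2-sulfanylethyl)amino in place of acetyl(1-carboxy-2-sulfanylethyl)amino on a saturated chain carbon bound to a carbonyl carbon).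

For the measured compounds named here, no measured step shows what this change does in this assay, so no step beyond the scatter is expected, in either direction, and the uncertainty remains wide. The expected step is a 1.2-fold lower number from compound 2 to compound 3 (0.09 log units; within the scatter). For compound 3 the estimated value is 2800 nM, with an expected range from 800 nM to 9000 nM.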

Compound 3, half-maximal inhibitory concentration: 3760 nM
The estimate for compound 3 lay 1.3-fold (0.13 log units) below the measured number; the range from low to high includes it.
By their numbers in this assay, from the lowest: compounds 1, 2 and 3 (each within the scatter of the next).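

In this assay, the first step read at this position, on a saturated chain carbon bound to a carbonyl carbon, is a 1.1-fold higher number from compound 2 to compound 3 (0.04 log units; within the scatter), with (1-(ethoxycarbonyl)-2-sulfanylethyl)amino in place of acetyl(1-carboxy-2-sulfanylethyl)amino. The exchange removes the acetyl and puts the ethoxycarbonyl where the carboxylic acid stood, and compound 3 still cannot be told apart from compound 2 in this assay. No available evidence bears on this result.

Because the acetyl and the carboxylic acid go in one step, the step does not show what each exchange does alone, and the acetyl kept alongside the ethoxycarbonyl would be one way to separate them. From the compounds shown here alone, whether a plain amine or a longer chain at this place would move the number beyond the scatter remains open.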